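Imidazole substitution pattern on the piperazine-linked core

The source may hold more compounds than are shown below. What is called first, only, known or untested is meant among the compounds shown, and "the series" means these compounds.

The series shares a core carrying a piperazine whose far nitrogen bears a methylene-linked heteroaryl. Compound 1 `Cc1ccc(CN2CCN(c3cccc4[nH]c(-c5ccc(C(C)(C)C)cc5)nc34)CC2)o1` carries 5-methylfuran-2-yl there; in an assay on isolated protein for displacement of a labelled ligand from Gonadotropin-releasing hormone receptor (Homo sapiens) (on this read-out higher numbers stand for weaker inhibition and lower numbers for stronger inhibition), compound 1 gives 705 nM. Compound 2 `CCn1cc(CN2CCN(c3cccc4[nH]c(-c5ccc(C(C)(C)C)cc5)nc34)CC2)nc1C` carries 1-ethyl-2-methyl-1H-imidazol-4-yl instead; in this assay compound 2 gives 10 nM. The step of a 71-fold lower number from compound 1 to compound 2 (1.85 log units; beyond the scatter) is the only measured one and is large. On these two numbers compound 2 stands lowest.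

Compound 3 `CCCn1c(CC)nc(C)c1CN1CCN(c2cccc3[nH]c(-c4ccc(C(C)(C)C)cc4)nc23)CC1` is not yet measured. The change is 2-ethyl-4-methyl-1-propyl-1H-imidazol-5-yl in place of 1-ethyl-2-methyl-1H-imidazol-4-yl on a saturated chain carbon bound to an amine nitrogen in a ring. Among the compounds with values here, no measured step alters the substitution pattern or the attachment point of an imidazole; the one step known, a 71-fold lower number from compound 1 to compound 2 (1.85 log units; beyond the scatter), concerns an exchange of ring type, so its size says little about the present move, in which the imidazole itself is retained and only its alkyl groups and attachment differ. The expectation is therefore a step near or within the scatter, a 1.5-fold higher number from compound 2 to compound 3 (0.18 log units; within the scatter), with the direction open. In this assay compound 3 is expected at 15 nM, with a range from 3 nM to 80 nM.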

Compound 3, half-maximal inhibitory concentration: 57 nM
Compound 3: the middle estimate sits 3.8-fold (0.58 log units) below what was measured; the measured number falls inside the stated range.
By their numbers in this assay, from the lowest: compound 2; then compound 3; then compound 1.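

Working notes on the imidazole position: keeping the imidazole does not make this position indifferent to how the ring is substituted and attached. In this assay the exchange of 1-ethyl-2-methyl-1H-imidazol-4-yl for 2-ethyl-4-methyl-1-propyl-1H-imidazol-5-yl, which takes the group from 8 to 11 heavy atoms, gives a 5.7-fold higher number from compound 2 to compound 3 (0.76 log units; beyond the scatter). Compound 3 nevertheless keeps much of the advantage over the furan, with a 12-fold lower number from compound 1 to compound 3 (1.09 log units; beyond the scatter), so among these three compounds both imidazoles stand ahead of 5-methylfuran-2-yl, though no evidence is at hand on what lies behind either step.

The step from compound 2 to compound 3 changes the attachment point and the alkyl groups together, so the share of each in the loss stays unresolved, and a single change, such as a propyl in place of the ethyl on the ring nitrogen with the attachment kept, would be needed to separate them. Also open, as far as these compounds go, is how the position responds to a longer chain such as butyl on that nitrogen, or to a primary amine or a carboxylic acid carried on the imidazole.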